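Swapping Fluorines for Hydroxyls on the Benzyl Group

The compounds below may be only part of what the source reports. "The series", "measured", "known", "first", "only" and "open" are said of these compounds alone.

Measured in a functional assay on HOS cells (Homo sapiens) for antiproliferative activity, with a stated time of 72 h; a lower number here means a stronger inhibitor, a higher number a weaker inhibitor:
Compound 1 `OC[C@H]1O[C@@H](n2cnc3c(NCc4cccc(F)c4)ncnc32)[C@H](O)[C@@H]1O`: > 166000 nM
Compound 2 `OC[C@H]1O[C@@H](n2cnc3c(NCc4ccc(F)cc4F)ncnc32)[C@H](O)[C@@H]1O`: > 166000 nM

Both entries are limits of the assay and not numbers. Compound 2 stands at > 166000 nM, which is such a limit. It shares that position with compound 1, as the limit of > 166000 nM in this assay, at which 2 of the 2 values shown sit, shows, so no true potency is known for either compound.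

Compound 3 `OC[C@H]1O[C@@H](n2cnc3c(NCc4cc(O)cc(O)c4)ncnc32)[C@H](O)[C@@H]1O` keeps the shared core but has 3,5-dihydroxyphenyl in place of 2,4-difluorophenyl on a saturated chain carbon bound to a nitrogen on an aromatic ring. Both rings are the same size, while the hydroxyl groups add the hydrogen-bond donors and acceptors counted in that change.

Among the measured compounds shown here, the only measured step that bears on this is a step that the two limits leave unreadable from compound 1 to compound 2. It gives neither a size nor a direction to carry over, so no real step is expected in this assay. Compound 3 will most likely be reported as a limit too.

The expected step is a number no higher from compound 2 to compound 3 (the limit leaves the size open). For compound 3 the estimate is 166000 nM, with an expected range of 60000 nM to 350000 nM.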

Compound 3, half-maximal inhibitory concentration: > 166000 nM
Compound 3 ended at the assay's limit; the forecaster's own chance of this, stated with the estimate: 75%; the middle value sits exactly at the limit.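

Compound 3 also sits at a limit of the assay and not at a number, so no step can be read between it and compound 1 or compound 2: the limit of > 166000 nM in this assay, at which 3 of the 3 values shown sit.

As far as these compounds go, what stays open is the true potency of all three compounds in this assay, and so whether 3,5-dihydroxybenzyl differs at all from 2,4-difluorobenzyl there.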